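This account rests on a few compounds, and the source may have more. Where it says the series, first, only, none or still open, it means among the compounds named here.

Of the compounds shown here, three built on one shared core have been measured in an assay for binding affinity to adenosine receptor A1 (Rattus norvegicus), read by radioligand binding; a lower number here means a stronger inhibitor, a higher number a weaker inhibitor. Compound 1 `Cn1c(=O)c2c(nc(-c3ccc(C(F)(F)F)cc3)n2C)n(C)c1=O` gives 17000 nM in this assay, and compound 2 `C=CCn1c(=O)c2c(nc(-c3ccc(C(F)(F)F)cc3)n2C)n(C)c1=O` gives 5700 nM; the two differ in one place only, and that single change brought a 3.0-fold lower number from compound 1 to compound 2 (0.47 log units; beyond the scatter). Compound 3 `Cn1c(=O)c2nc(C3CCC3)[nH]c2n(C)c1=O` gives 190 nM, the lowest number of the three and beyond the scatter from both compound 2 and compound 1, so among these three it is the strongest inhibitor.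

Compound 4 `CCC/C=C/c1nc2c(=O)n(C)c(=O)n(C)c2[nH]1` has not yet been measured. It differs from compound 3 by pent-1-en-1-yl in place of cyclobutyl on an aromatic carbon. Going by the values given here, no measured step touches this position: the single step measured, from compound 1 to compound 2, concerns a chain on a ring nitrogen in a pair that carries an aromatic substituent where compound 3 carries cyclobutyl, so it gives no direct guide. Compound 1 and compound 2 show only that a far weaker result is possible when that position bears a larger aromatic group. A modestly weaker result is expected for compound 4, a step of a 2.6-fold higher number from compound 3 to compound 4 (0.42 log units; beyond the scatter), with wide uncertainty. Compound 4 is estimated at 500 nM, within a range from 100 nM to 3000 nM.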

Compound 4, inhibition constant: 380 nM
The estimate for compound 4 lay 1.3-fold (0.12 log units) above the measured number; measured number inside the range.
By their numbers in this assay, from the lowest: compounds 3 and 4 (each within the scatter of the next); then compound 2; then compound 1.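

In this assay, putting pent-1-en-1-yl in place of cyclobutyl on this aromatic carbon gives a 2.0-fold higher number from compound 3 to compound 4 (0.30 log units; within the scatter), so the two compounds cannot be told apart by this measurement. For this pair, the position can therefore carry either a four-membered ring of carbon or an open chain with a double bond and no ring, and the numbers stay within the usual scatter of each other; a ring at this spot is not needed for a value of this size on the shared core. No supporting measurement is available that could explain why these two groups read alike.

The compounds shown leave open how far this tolerance extends, for instance whether a saturated pentyl chain, a longer chain, or a chain ending in an amine or a carboxylic acid would read like these two groups at this position. They also leave open whether placing an allyl group on the ring nitrogen, the one alteration measured in the pair of compound 1 and compound 2, would have a similar effect when cyclobutyl or pent-1-en-1-yl occupies the aromatic carbon.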